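This account rests on a few compounds, and the source may have more. Where it says the series, first, only, none or still open, it means among the compounds named here.

Of the compounds shown here, three that share one core have been tested so far in a functional assay on MGC-803 cells (Homo sapiens) for cytotoxicity, read by MTT assay, with a stated time of 72 h; a lower number here means a stronger inhibitor, a higher number a weaker inhibitor. There, compound 1 `O=C1C(=Cc2ccc(O)cc2)C(=O)N(c2ccc(Cl)cc2)N1c1ccc(Cl)cc1` gives 19500 nM, compound 2 `O=C1C(=Cc2ccc(Br)cc2)C(=O)N(c2ccc(Cl)cc2)N1c1ccc(Cl)cc1` gives 16900 nM and compound 3 `COc1cccc(C=C2C(=O)N(c3ccc(Cl)cc3)N(c3ccc(Cl)cc3)C2=O)c1O` gives 24300 nM. Compound 3 therefore stands level with the other two, since its gap to each lies within the usual scatter of repeated measurements.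

Compound 4 `COc1cccc(C=C2C(=O)N(c3ccc(Cl)cc3)N(c3ccc(Cl)cc3)C2=O)c1OC` differs from compound 3 in one place: methyl in place of hydrogen on an oxygen on an aromatic ring. This puts methyl in place of hydrogen on an oxygen on an aromatic ring, turning 2-hydroxy-3-methoxyphenyl into 2,3-dimethoxyphenyl.

Among the compounds with values here, no measured step makes this exact change, so the evidence is indirect. The closest comparisons exchange the whole aromatic group, as in a 1.2-fold higher number from compound 1 to compound 3 (0.10 log units; within the scatter) and a 1.4-fold higher number from compound 2 to compound 3 (0.16 log units; within the scatter). A third, with bromo in place of hydroxy, is a 1.2-fold lower number from compound 1 to compound 2 (0.06 log units; within the scatter). All three steps are small and lie within the scatter. On that basis, no step beyond the scatter is expected in this assay, although three compounds are a thin base and none of them has a hydroxy capped in this way.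

The expected change is a 1.1-fold lower number from compound 3 to compound 4 (0.04 log units; within the scatter). Compound 4 is estimated at 22000 nM, with an expected range from 11000 nM to 42000 nM.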

Compound 4, half-maximal inhibitory concentration: 29600 nM
For compound 4 the middle estimate is 1.3-fold (0.13 log units) below the measured one; the measured number falls inside the stated range.
By their numbers in this assay, from the lowest: compounds 2, 1, 3 and 4 (each within the scatter of the next).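

Within the data shown here, replacing the hydrogen on this oxygen with methyl, which turns hydroxy into methoxy, gives the first direct reading of this change in this assay (a 1.2-fold higher number from compound 3 to compound 4 (0.09 log units; within the scatter)). Compound 4 also stays within the scatter of the two compounds that carry a different aromatic group, as the exchanges of the whole group show (a 1.8-fold higher number from compound 2 to compound 4 (0.24 log units; within the scatter); a 1.5-fold higher number from compound 1 to compound 4 (0.18 log units; within the scatter)), so among these four compounds a free hydroxy at this place is not needed to keep the number in the same range. Nothing measured here explains why capping this oxygen leaves so little mark on the number.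

As far as these compounds go, it remains open whether a larger group on this oxygen, such as a longer chain ending in an amine or a carboxylic acid, would produce a step beyond the scatter. Every compound shown also keeps the same shared core with its chlorine-bearing rings, and no pair here differs by more than the scatter, so these compounds do not reveal which part of the structure the cytotoxicity depends on.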